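A Chloro Group Enters the Anilino Ring of Compound 3

The source may report more compounds than this note shows. Statements on the series, on what has been measured and on what is new or still open speak of the compounds shown alone.

Of the compounds shown here, three built on one shared core have been measured in a functional assay on the whole organism (strain albino) for inhibition, with Rattus norvegicus as the target, read by paw edema, with stated times of 1 h and 3 h, at a dose of 100 mg/kg by the oral route; on this read-out lower numbers stand for a weaker effect and higher numbers for a stronger effect at the one dose given. Compound 1 `O=C(CSc1nc(-c2ccc(O)cc2)c(C(=O)O)c(=O)[nH]1)Nn1c(COc2ccc(Cl)cc2Cl)nc2ccccc2c1=O` gives 38.6%. Compound 2 `N#Cc1c(Cl)nc(SCC(=O)Nn2c(COc3ccc(Cl)cc3Cl)nc3ccccc3c2=O)nc1-c1ccccc1` gives 68.4% in this assay. Compound 3 `N#Cc1c(Nc2ccccc2)nc(SCC(=O)Nn2c(COc3ccc(Cl)cc3Cl)nc3ccccc3c2=O)nc1-c1ccccc1` gives 78.1% in this assay. On these numbers compound 3 stands highest of the three: its separation from compound 2 is a number 9.7 percentage points higher from compound 2 to compound 3 (within the scatter), while its separation from compound 1 lies beyond the scatter.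

Compound 4 `N#Cc1c(Nc2ccc(Cl)cc2)nc(SCC(=O)Nn2c(COc3ccc(Cl)cc3Cl)nc3ccccc3c2=O)nc1-c1ccccc1` is the next compound, and it differs from compound 3 by chloro in place of hydrogen on an aromatic carbon. Among the measured compounds shown here, no measured step bears directly on this change. For the measured compounds named here, the only step recorded, a number 9.7 percentage points higher from compound 2 to compound 3 (within the scatter), concerns anilino in place of chloro on the shared core and is a change of a different kind, so it offers no guide to what a chloro entering the anilino ring itself will do.

With nothing to set against it, compound 4 is expected to stay near the number of compound 3, and is estimated at 79%, with a range from 64% to 92%. The step this estimate means, a number 0.9 percentage points higher from compound 3 to compound 4 (within the scatter), is expected to fall within the scatter, in no clear direction.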

Compound 4, a percentage reported as inhibition, in the whole organism at one dose (the size of the read-out at that dose, not a potency): 59.7%
For compound 4 the middle estimate is 19.3 percentage points above the measured one, outside the stated range (below it).
By their numbers in this assay, from the lowest: compound 1; then compounds 4, 2 and 3 (each within the scatter of the next, the first and the last beyond it).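

In this assay the anilino ring proves sensitive to substitution at this place, which compounds 1, 2 and 3, none of them carrying a group on that ring, could not show. The chloro entering on an aromatic carbon, para to a large group, gives a number 18.4 percentage points lower from compound 3 to compound 4 (beyond the scatter) and so marks a change that a single heavy atom is enough to produce. Set against the chloro on the shared core, the (4-chlorophenyl)amino group gives a number 8.7 percentage points lower from compound 2 to compound 4 (within the scatter) as its step, so compound 4 does not separate from compound 2 on these numbers, and nothing at hand accounts for the drop from the unsubstituted anilino.

The compounds shown leave open whether the step belongs to chloro itself or would also appear with another group at this same place, such as fluoro, methyl or methoxy. They also leave open how an aliphatic amine such as morpholine would read in place of the anilino group on the shared core, and, with a single dose given, whether the weaker effect of compound 4 at that dose would also appear at any other dose.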